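This account rests on a few compounds, and the source may have more. Where it says the series, first, only, none or still open, it means among the compounds named here.

The three measured compounds share a core and were tested in a functional assay on DU-145 cells (Homo sapiens) for inhibition, read by MTT assay, with stated times of 18 h and 4 h; on this read-out lower numbers stand for stronger inhibition and higher numbers for weaker inhibition. Compound 1 `CCCOP(=O)(O)OCCSC(=S)N1CCCC1` gives > 100000 nM, which is a limit of the assay rather than a number. Compound 2 `CCCCCCOP(=O)(O)OCCSC(=S)N1CCCC1` likewise gives > 100000 nM, again only a limit. Compound 3 `CCCCCCOP(=O)(O)OCCSC(=S)N1CCN(C)CC1` returns > 100000 nM, once more a limit. Because all three sit at the limit of > 100000 nM in this assay, at which 3 of the 3 values shown sit, the steps among them cannot be read: the change from compound 2 to compound 1, (hydrogen in place of propyl on a saturated chain carbon, three bonds along the chain from an oxygen on an unsaturated carbon), leaves a step that the two limits leave unreadable from compound 2 to compound 1, and the change from compound 2 to compound 3, (4-methylpiperazin-1-yl in place of pyrrolidin-1-yl on a thiocarbonyl carbon), leaves a step that the two limits leave unreadable from compound 2 to compound 3.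

Compound 4 `CCCOP(=O)(O)OCCSC(=S)N1CCN(C)CC1` has not yet been measured in this assay. It differs from compound 3 by hydrogen in place of propyl on a saturated chain carbon, three bonds along the chain from an oxygen on an unsaturated carbon, the same change that was made from compound 2 to compound 1, and the cores of compound 3 and compound 4 differ from those of compound 2 and compound 1 by 4-methylpiperazin-1-yl in place of pyrrolidin-1-yl on a thiocarbonyl carbon. Since the earlier occurrence of this change, from compound 2 to compound 1, could not be sized because both values sit at the limit of > 100000 nM in this assay, at which 3 of the 3 values shown sit, the step from compound 3 to compound 4 is expected to be a step that the limit leaves unreadable from compound 3 to compound 4, and that expectation rests only on compound 3 giving > 100000 nM. The estimated value for compound 4 in this assay is therefore 150000 nM, with a plausible range from 50000 nM to 500000 nM, and most likely the assay will again report only a limit.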

Compound 4, half-maximal inhibitory concentration: > 100000 nM
Compound 4 ended at the assay's limit (the forecaster's own chance of this, stated with the estimate: 85%); the middle value lies beyond the limit too.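

Compound 4 gives > 100000 nM, which is a limit and not a number. No step from compound 3 to compound 4 can be read, because both values sit at the same limit: the limit of > 100000 nM in this assay, at which 4 of the 4 values shown sit.

The compounds shown leave open whether any of them has a measurable effect in this assay, and how the hexyl and propyl chains, or the pyrrolidin-1-yl and 4-methylpiperazin-1-yl groups, compare.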